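Adding a second chloro to a pyrazole carboxanilide

The source may report more compounds than this note shows. Statements on the series, on what has been measured and on what is new or still open speak of the compounds shown alone.

Two compounds share one core. In a functional assay on MCF7 cells (Homo sapiens) for cytotoxicity, read by MTT assay, with a stated time of 48 h (a lower number here means a stronger inhibitor, a higher number a weaker inhibitor), compound 2 `O=C(Nc1ccccc1)c1cn(-c2ccccc2)nc1-c1ccc(Cl)cc1` gives 2340 nM, and compound 1 `O=C(Nc1ccc(Cl)cc1)c1cn(-c2ccccc2)nc1-c1ccccc1` gives 3860 nM, a gap that lies within the scatter, so the two stand together. Compound 3 `O=C(Nc1ccc(Cl)cc1)c1cn(-c2ccccc2)nc1-c1ccc(Cl)cc1` differs from compound 2 by chloro in place of hydrogen on an aromatic carbon. For the measured compounds named here, no step between measured compounds is known for this change, and compound 1 already carries such a chloro on the anilide while sitting alongside compound 2. Compound 3 is therefore expected to stay close, with a 1.2-fold lower number from compound 2 to compound 3 (0.07 log units; within the scatter) amounting to little beyond the scatter. The estimate for compound 3 in this assay is 2000 nM, within 800 nM to 5000 nM.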

Compound 3, half-maximal inhibitory concentration: 3750 nM
Beside the measured number, compound 3's estimate is 1.9-fold (0.27 log units) below it; the range from low to high includes it.
By their numbers in this assay, from the lowest: compounds 2, 3 and 1 (each within the scatter of the next).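

In this assay, chloro in place of hydrogen can now be read as a step at two places on the shared core. Going from anilino to (4-chlorophenyl)amino gives a 1.6-fold higher number from compound 2 to compound 3 (0.20 log units; within the scatter), and going from phenyl to 4-chlorophenyl gives a 1.0-fold lower number from compound 1 to compound 3 (0.01 log units; within the scatter), so neither chloro separates the compounds, and a second chloro adds nothing that exceeds the scatter. No measurement is at hand that would explain this.

The compounds shown leave open whether an amine, a carboxylic acid or a methoxy group in place of chloro at either place would give a step beyond the scatter.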